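Trimming the Side Chain of an Acylated Amino Acid Anilide

The source may report more compounds than this note shows. Statements on the series, on what has been measured and on what is new or still open speak of the compounds shown alone.

Compound 2 `CCC(C)C(C(=O)Nc1ccc(C(C)=O)cc1)N(C(=O)c1ccccc1)S(=O)(=O)c1ccccc1` and compound 1 `CC(=O)c1ccc(NC(=O)C(CC(C)C)N(C(=O)c2ccccc2)S(=O)(=O)c2ccccc2)cc1` share one core and differ only in the group on the saturated chain carbon bound to an amide-type nitrogen and a carbonyl carbon. In a functional assay for inhibition, read by spectrophotometry, with a stated time of 20 min, tested at 1 mg/mL (a higher number here means a stronger effect of the compound at the concentration tested, a lower number a weaker effect), compound 1 gives 27.7%. In this assay, for the measured compounds named here, compound 2 gives 9.71%, the lowest of the two numbers; the single measured step is a number 18 percentage points lower from compound 1 to compound 2 (beyond the scatter). Compound 3 `CC(=O)c1ccc(NC(=O)C(C(C)C)N(C(=O)c2ccccc2)S(=O)(=O)c2ccccc2)cc1` has not yet been measured. It differs from compound 2 in one place: hydrogen in place of methyl on a saturated chain carbon, three bonds along the chain from an amide-type nitrogen and a carbonyl carbon. Going by the values given here, the only step at hand, isobutyl to sec-butyl, shows that a change in this chain can move the number by a modest amount, but it does not show which way a shorter chain would go, and the step it shows is itself only modest. The expected step is therefore a number 7.3 percentage points higher from compound 2 to compound 3 (within the scatter), a move within the scatter. Compound 3 is estimated at 17%, with a range from 4% to 35%.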

Compound 3, a percentage reported as inhibition, at one concentration (the size of the read-out at that concentration, not a potency): 32.1%
For compound 3 the middle estimate is 15.1 percentage points below the measured one; the range from low to high includes it.
By their numbers in this assay, from the lowest: compound 2; then compounds 1 and 3 (each within the scatter of the next).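

In this assay, the change from sec-butyl to isopropyl gives a number 22.4 percentage points higher from compound 2 to compound 3 (beyond the scatter), so removing this one methyl moves the number by more than the scatter. Isopropyl in place of isobutyl gives a number 4.4 percentage points higher from compound 1 to compound 3 (within the scatter), which leaves compound 1 and compound 3 indistinguishable here and makes sec-butyl, among these three groups, the only one that stands apart. Nothing measured here explains why sec-butyl stands apart from the other two groups.

The compounds shown leave open how a plain methyl, a longer chain such as n-hexyl, or a benzyl group would read on this saturated chain carbon. They also leave open whether an amine or a carboxylic acid at the end of the chain would be tolerated in this read-out.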